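Swapping hydroxy for fluoro on compound 2

A few compounds are considered here, and "the series" means these few. Any claim that something is new, unique, unknown or untested is made for them only; others in the source may bear on it.

Readings so far in a functional assay on MT4 cells (Homo sapiens) for cytotoxicity, read by MTT assay (on this read-out lower numbers stand for higher toxicity in this test and higher numbers for lower toxicity in this test), for three compounds

Compound 1 `Cc1c(O)nc(S(=O)(=O)Cc2ccc([N+](=O)[O-])cc2)nc1Cc1c(Cl)cccc1Cl` gives > 53000 nM as a limit
Compound 2 `Cc1c(O)nc(SCc2ccc(O)cc2)nc1Cc1c(Cl)cccc1Cl` gives 41000 nM as a number
Compound 3 `Cc1c(O)nc(SCc2ccc(C#N)cc2)nc1Cc1c(F)cccc1F` gives > 65000 nM as a limit

Among the compounds with values here, compound 2 is the only one with a true number in this assay and the other two readings are limits, so no ranking among the three can be drawn.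

The next compound, compound 4 (`Cc1c(O)nc(SCc2ccc(F)cc2)nc1Cc1c(Cl)cccc1Cl`), differs from compound 2 in one place, on an aromatic carbon of a six-membered aromatic ring of carbon only, para to a large group. There, fluoro stands in place of hydroxy, which turns 4-hydroxybenzyl into 4-fluorobenzyl (fluoro in place of hydroxy on an aromatic carbon).

Within the data shown here, no two measured compounds differ in just one place, so no measured step shows how large such a change might be. Compound 3 lacks the 4-hydroxybenzyl group, and its reading is a limit (> 65000 nM). Compound 1 lacks it too, and its reading is also a limit (> 53000 nM).

The estimated change a 1.2-fold higher number from compound 2 to compound 4 (0.07 log units; within the scatter) is expected to stay within the usual scatter, with a slight lean towards lower toxicity. The estimate for compound 4 is 48000 nM (expected range 20000 nM to 95000 nM) and the reading may well come back as a limit.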

Compound 4, half-maximal cytotoxic concentration: > 61000 nM
Compound 4 gave a limit, no number; the forecaster's own chance of this, stated with the estimate: 55%; middle value at least 1.2-fold (0.10 log units) from the limit.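

In this assay, within the data shown here, this is the first step that changes a single place on the shared core: hydroxy gives way to fluoro on the aromatic carbon of the benzyl ring, and everything else stays the same. The step reads as an at least 1.4-fold higher number from compound 2 to compound 4 (0.17 log units; that floor lies within the scatter), and that floor lies within the usual scatter, so a real drop in toxicity cannot be claimed, although this change at this position shows no sign of raising toxicity in the test. The reading of compound 4 is a limit rather than a number, which leaves the step with a floor but no true size: the limit of > 61000 nM in this assay, at which 1 of the 4 values shown sits.

From the compounds shown here alone, how far compound 4 really sits from compound 2 stays unknown, and the other limits give no second number to compare it with. Also open, going by these compounds, is what an amine or a carboxylic acid on the same aromatic carbon would do, and whether any such group would bring the toxicity reading down to a true number on this core.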